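Swapping the urea aryl group: from dichloro to trifluoromethyl

The source may report more compounds than this note shows. Statements on the series, on what has been measured and on what is new or still open speak of the compounds shown alone.

Measured in a functional assay on MDA-MB-231 cells (Homo sapiens) for inhibition, read by sulforhodamine B assay, with a stated time of 48 h (a lower number here means a stronger inhibitor of growth, a higher number a weaker inhibitor of growth), so far:
- compound 1, `O=C(Nc1cccc(-n2cc(-c3ccncc3)c(-c3ccc(Cl)c(O)c3)n2)c1)Nc1cccc(C(F)(F)F)c1`: 26800 nM
- compound 2, `COc1cc(-c2nn(-c3cccc(NC(=O)Nc4cc(C(F)(F)F)cc(C(F)(F)F)c4)c3)cc2-c2ccncc2)ccc1Cl`: 1410 nM
- compound 3, `COc1cc(-c2nn(-c3cccc(NC(=O)Nc4ccc(Cl)c(Cl)c4)c3)cc2-c2ccncc2)ccc1Cl`: 1920 nM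

Compound 3 holds the second highest of the three numbers in this assay. Its nearest neighbour is compound 2, whose number is lower by an amount that lies within the scatter of repeated measurements, so the two cannot be ranked against each other. Compound 1 stands far away with a much higher number, a gap beyond the scatter; compound 1 carries the same aryl group at the urea as the new compound does, but differs from it elsewhere in the structure, so it gives no clean guide.

The new compound 4, `COc1cc(-c2nn(-c3cccc(NC(=O)Nc4cccc(C(F)(F)F)c4)c3)cc2-c2ccncc2)ccc1Cl`, is made from compound 3 by one change: 3-(trifluoromethyl)phenyl in place of 3,4-dichlorophenyl on an amide-type nitrogen. For the measured compounds named here, no measured pair shows exactly this swap. Compound 2 and compound 3, with two different aryl groups on that nitrogen, sit within the scatter of each other, which suggests the urea aryl group tolerates variation here. The step of a 1.3-fold higher number from compound 3 to compound 4 (0.11 log units; within the scatter) is therefore expected to be small, towards a slightly higher number if anything, not beyond the scatter. Compound 4 is estimated at 2500 nM in this assay, within 900 nM to 7000 nM.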

Compound 4, concentration for total growth inhibition: 2370 nM
For compound 4 the middle estimate is 1.1-fold (0.02 log units) above the measured one, within the range that was stated.
By their numbers in this assay, from the lowest: compounds 2, 3 and 4 (each within the scatter of the next); then compound 1.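

In this assay the aryl group on the amide-type nitrogen can change with no readable effect: 3-(trifluoromethyl)phenyl in place of 3,4-dichlorophenyl gives a 1.2-fold higher number from compound 3 to compound 4 (0.09 log units; within the scatter) and removing one trifluoromethyl gives a 1.7-fold higher number from compound 2 to compound 4 (0.23 log units; within the scatter) so compound 2, compound 3 and compound 4 cannot be ranked. A much larger step lies elsewhere, since methyl in place of hydrogen on an oxygen on an aromatic ring gives an 11-fold lower number from compound 1 to compound 4 (1.05 log units; beyond the scatter) and, among these compounds, only that oxygen substituent moves the number beyond the scatter. Nothing measured here explains the size of that step.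

Still open, as far as these compounds go, is whether an aryl group carrying an amine or a carboxylic acid on that nitrogen would also leave the number unmoved. Open too, from the compounds shown here alone, is whether ethyl or a longer chain on that oxygen would keep the number of compound 4.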